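The compounds below may be only part of what the source reports. "The series", "measured", "known", "first", "only" and "open" are said of these compounds alone.

Working notes on the series.

Among the measured compounds shown here, compound 2 `CCCCCCNC(=O)/N=C(\N)NCCCc1sc(N)nc1C` gives 28.8 nM in an assay on membranes from Sf9 cells for displacement of a labelled ligand from histamine H2 receptor (Homo sapiens), read by scintillation counting, with a stated time of 60 min (on this read-out lower numbers stand for stronger inhibition and higher numbers for weaker inhibition), and so stands highest of the two numbers in hand; its nearest neighbour is compound 1 `Cc1nc(N)sc1CCCN/C(N)=N/C(=O)N[C@H](C)c1ccccc1`, which in this assay gives 17.8 nM, and the single measured step, a 1.6-fold higher number from compound 1 to compound 2 (0.21 log units; within the scatter), is within the scatter. Compound 3 `Cc1nc(N)sc1CCCN/C(N)=N/C(=O)NCc1ccccc1` is not yet measured. The change from compound 2 is phenyl in place of pentyl on a saturated chain carbon bound to an amide-type nitrogen, that is hexyl to benzyl on the amide-type nitrogen. For the measured compounds named here, the only step that bears on this is the one between hexyl and 1-phenylethyl at the same nitrogen, and it was small, so an aromatic ring against a saturated chain at this position has so far moved this assay little. The step of a 1.4-fold lower number from compound 2 to compound 3 (0.16 log units; within the scatter) is therefore expected to lie within the scatter, if anything toward a lower number. Compound 3 is estimated at 20 nM, with a range from 8 nM to 50 nM.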

Compound 3, inhibition constant: 69.2 nM
The estimate for compound 3 lay 3.5-fold (0.54 log units) below the measured number, and the stated range ends below it.
By their numbers in this assay, from the lowest: compounds 1 and 2 (each within the scatter of the next); then compound 3.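

In this assay, the step of a 2.4-fold higher number from compound 2 to compound 3 (0.38 log units; beyond the scatter) shows that phenyl in place of pentyl at this carbon is not neutral, so the small step from hexyl to 1-phenylethyl did not mean that the saturated chain and the aromatic ring are interchangeable here. The step of a 3.9-fold higher number from compound 1 to compound 3 (0.59 log units; beyond the scatter) shows that the methyl on the saturated carbon bound to the amide-type nitrogen and the aromatic carbon counts: with hydrogen there, the number rises beyond the scatter, while compound 1 and compound 2 remain within the scatter of each other. No measurement in hand gives a reason for either step.

The compounds shown leave open how far this effect depends on the size of the group on that carbon, or on the arrangement of its methyl. An ethyl at that carbon, the mirror-image methyl compound, or a longer chain carrying the phenyl would test this.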